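Ether substituent variation on the shared core

A few compounds are considered here, and "the series" means these few. Any claim that something is new, unique, unknown or untested is made for them only; others in the source may bear on it.

Compound 3 `CCc1sc(CCc2cc(OCC(C)(C)C)cc(NCc3cc(Cl)cc(NC(=O)OC(C)C)c3)n2)nc1C` stands second highest of the three numbers in an assay on cells for binding affinity to Neuropeptide Y receptor type 1 (Homo sapiens) (on this read-out lower numbers stand for stronger inhibition and higher numbers for weaker inhibition), giving 55 nM. Its nearest neighbour is compound 1 `CCc1sc(CCc2cc(OC)cc(NCc3cc(Cl)cc(NC(=O)OC(C)C)c3)n2)nc1C`, which gives 234 nM, and the furthest is compound 2 `CC/C=C\CCOc1cc(CCc2nc(C)c(CC)s2)nc(NCc2cc(Cl)cc(NC(=O)OC(C)C)c2)c1`, which gives 4.7 nM. The steps of a 4.3-fold lower number from compound 1 to compound 3 (0.63 log units; beyond the scatter) and a 12-fold higher number from compound 2 to compound 3 (1.07 log units; beyond the scatter) both turn on the group carried by this oxygen, so the position is clearly sensitive. Compound 4 `CCc1sc(CCc2cc(OC3CCOCC3)cc(NCc3cc(Cl)cc(NC(=O)OC(C)C)c3)n2)nc1C` carries oxan-4-yl in place of neopentyl on an oxygen on an aromatic ring. No measured step exchanges one saturated group for another of comparable size at this oxygen, so the direction cannot be read from the shown pairs. A small change is expected, and compound 4 is estimated at 60 nM, range 15 nM to 250 nM. That expected step is a 1.1-fold higher number from compound 3 to compound 4 (0.04 log units; within the scatter).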

Compound 4, half-maximal inhibitory concentration: 4.4 nM
Compound 4: the middle estimate sits 14-fold (1.13 log units) above what was measured; the whole stated range lies above it.
By their numbers in this assay, from the lowest: compounds 4 and 2 (each within the scatter of the next); then compound 3; then compound 1.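

In this assay the group on this oxygen need not be an open chain: a 13-fold lower number from compound 3 to compound 4 (1.10 log units; beyond the scatter) and a 53-fold lower number from compound 1 to compound 4 (1.73 log units; beyond the scatter) put oxan-4-yl well ahead of neopentyl and methyl, while a 1.1-fold lower number from compound 2 to compound 4 (0.03 log units; within the scatter) leaves it level with hex-3-en-1-yl. The earlier compounds shown here allowed a reading in which only the hex-3-en-1-yl chain reached this level, but compound 4 reaches it with a ring. No available evidence explains the step.

The compounds shown do not separate the effect of the ring from that of its oxygen. A cyclohexyl or piperidin-4-yl group on this oxygen would bear on that question.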